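This account rests on a few compounds, and the source may have more. Where it says the series, first, only, none or still open, it means among the compounds named here.

Measured so far in a functional assay on MCF7 cells (Homo sapiens) for cytotoxicity, read by CCK-8 assay, with a stated time of 48 h; on this read-out lower numbers stand for stronger inhibition and higher numbers for weaker inhibition:
- compound 1 `CC(C)(C)c1cc(C(C)(C)C)c2oc(=O)c(/C=N/c3ccc(S(N)(=O)=O)cc3)c(Cl)c2c1`: 16 nM
- compound 2 `CC(C)(C)c1cc(C(C)(C)C)c2oc(=O)c(/C=N/c3ccc(S(=O)(=O)NC(=N)N)cc3)c(Cl)c2c1`: 18 nM
- compound 3 `Cc1cc(NS(=O)(=O)c2ccc(/N=C/c3c(Cl)c4cc(C(C)(C)C)cc(C(C)(C)C)c4oc3=O)cc2)no1`: 64 nM

Compound 3 gives the highest of the three numbers in this assay. Its nearest neighbour is compound 2, with the step of a 3.6-fold higher number from compound 2 to compound 3 (0.55 log units; beyond the scatter); furthest is compound 1, with the step of a 4.0-fold higher number from compound 1 to compound 3 (0.60 log units; beyond the scatter). Both steps lie beyond the scatter and both put a group onto the same sulfonamide nitrogen, in place of hydrogen or of a small group without a ring.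

Compound 4 `Cc1ccnc(NS(=O)(=O)c2ccc(/N=C/c3c(Cl)c4cc(C(C)(C)C)cc(C(C)(C)C)c4oc3=O)cc2)n1` differs from compound 3 by 4-methylpyrimidin-2-yl in place of 5-methyl-1,2-oxazol-3-yl on a sulfonamide nitrogen. Among the compounds with values here, no measured step exchanges one ring for another at this position; the two steps that reach compound 3 only show that a ring on this nitrogen, as against hydrogen or the three-atom group, comes with a modestly higher number. Since compound 4 keeps a ring there, the expected step of a 1.1-fold higher number from compound 3 to compound 4 (0.04 log units; within the scatter) is no larger than the scatter, in no fixed direction. Compound 4 is therefore estimated at 70 nM, within the range 30 nM to 170 nM.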

Compound 4, half-maximal inhibitory concentration: 32 nM
For compound 4 the middle estimate is 2.2-fold (0.34 log units) above the measured one; the measured number falls inside the stated range.
By their numbers in this assay, from the lowest: compounds 1, 2, 4 and 3 (each within the scatter of the next, the first and the last beyond it).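

In this assay, within the data shown here, the first exchange of one ring for another on the sulfonamide nitrogen, 4-methylpyrimidin-2-yl in place of 5-methyl-1,2-oxazol-3-yl, stays within the scatter (a 2.0-fold lower number from compound 3 to compound 4 (0.30 log units; within the scatter)), so the two rings are not told apart here. Unlike 5-methyl-1,2-oxazol-3-yl, 4-methylpyrimidin-2-yl stays within the scatter both of hydrogen (a 2.0-fold higher number from compound 1 to compound 4 (0.30 log units; within the scatter)) and of the ring-free group (a 1.8-fold higher number from compound 2 to compound 4 (0.25 log units; within the scatter)), so a ring on this nitrogen does not in itself bring a step beyond the scatter. No available evidence bears on this result.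

On these data alone, whether the methyl on either ring contributes remains open, as an unsubstituted pyrimidin-2-yl would be needed to test it. Also open, as far as these compounds go, is how a longer alkyl chain or an acetyl group on this nitrogen would compare.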